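The compounds below may be only part of what the source reports. "The series", "measured", "known", "first", "only" and "open" are said of these compounds alone.

Series notes. Compound 1 `CC/C(=C(/c1ccc(/C=C/C(=O)O)cc1)c1[nH]c2ccccc2c1Br)c1ccc(F)cc1Cl` and compound 2 `CC/C(=C(/c1ccc(/C=C/C(=O)O)cc1)c1[nH]c2ccccc2c1Cl)c1cc(Cl)sc1Cl` share a core and have both been run in a functional assay on MCF7 cells (Homo sapiens) for antiproliferative activity, read by luminescence and CellTiter-Glo, with a stated time of 5 days; a higher number here means a weaker inhibitor, a lower number a stronger inhibitor. In this assay compound 1 gives 8.53 nM, the lowest of the two numbers recorded so far; in this assay compound 2 gives 20 nM, a gap that lies beyond the usual scatter. Compound 2 differs from compound 1 in more than one place, so no single step can be read from that pair.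

Compound 3 `CC/C(=C(/c1ccc(/C=C/C(=O)O)cc1)c1cc2ccccc2[nH]1)c1ccc(F)cc1Cl` is the next entry and is still to be measured in this assay. Compared with compound 1 the change is hydrogen in place of bromo on an aromatic carbon. Within the data shown here, no measured pair isolates this change, so the direction is open. Compound 3 is expected to come out somewhat weaker than compound 1, with a step of a 2.9-fold higher number from compound 1 to compound 3 (0.47 log units; beyond the scatter) of modest size. The estimate for compound 3 in this assay is 25 nM, in a range from 8 nM to 80 nM.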

Compound 3, half-maximal inhibitory concentration: 21 nM
For compound 3 the middle estimate is 1.2-fold (0.08 log units) above the measured one; measured number inside the range.
By their numbers in this assay, from the lowest: compound 1; then compounds 2 and 3 (each within the scatter of the next).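

In this assay, among these compounds, the change from 3-bromo-1H-indol-2-yl to 1H-indol-2-yl gives the first step that can be read in one place: a 2.5-fold higher number from compound 1 to compound 3 (0.39 log units; beyond the scatter) is modest but beyond the scatter. The bromo on this aromatic carbon therefore accounts for a measurable part of the number for compound 1, while compound 3, without any group there, still gives 21 nM in this assay. Nothing measured here explains the step.

From the compounds shown here alone, whether methyl, a nitrile or an amine on this carbon would match bromo remains open. Chloro at this place appears only in compound 2, which differs from compound 1 in more than one place, so its contribution cannot be separated from the other change.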